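Swapping the ring on the amide carbonyl

The source may report more compounds than this note shows. Statements on the series, on what has been measured and on what is new or still open speak of the compounds shown alone.

Of the compounds shown here, three sharing one core have been tested in an assay on HEK293 cells for positive allosteric modulation of metabotropic glutamate receptor 5 (Homo sapiens), read by FLIPR, with a stated time of 1 h; on this read-out higher numbers stand for an effect only at larger amounts of compound and lower numbers for an effect already at smaller amounts. Compound 1 `O=C(C1CC1)N1CCc2nc(C#Cc3ccccc3)sc2C1` gives > 10000 nM, which is the limit of > 10000 nM in this assay, at which 1 of the 3 values shown sits, and not a number. Compound 2 `O=C(C1CCC(F)(F)CC1)N1CCc2nc(C#Cc3ccccc3)sc2C1` gives 70 nM. Compound 3 `O=C(C1CCCCO1)N1CCc2nc(C#Cc3ccccc3)sc2C1` gives 320 nM, the higher of the two numbers, set apart by a 4.6-fold higher number from compound 2 to compound 3 (0.66 log units; beyond the scatter). The steps of an at least 140-fold lower number from compound 1 to compound 2 (2.15 log units; beyond the scatter) and an at least 31-fold lower number from compound 1 to compound 3 (1.49 log units; beyond the scatter) show that the group on the carbonyl carbon matters greatly. Compound 4 `O=C(c1cccc(Cl)c1)N1CCc2nc(C#Cc3ccccc3)sc2C1` alters exactly this place: 3-chlorophenyl in place of oxan-2-yl on a carbonyl carbon. All measured steps concern this position, yet none involves an aromatic ring, so a shift beyond the scatter in this assay in either direction is plausible. Compound 4 is expected to give about 200 nM, between 40 nM and 2000 nM. The expected step is a 1.6-fold lower number from compound 3 to compound 4 (0.20 log units; within the scatter).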

Compound 4, half-maximal effective concentration: 8.7 nM
Compound 4: middle estimate off by 23-fold (1.36 log units), on the high side; measured number below the stated range.
By their numbers in this assay, from the lowest: compound 4; then compound 2; then compound 3. At a limit, above all of these: compound 1.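

Going by these compounds alone, the aromatic 3-chlorophenyl group gives the lowest number so far at this position, and the change to it from either non-aromatic six-membered ring is beyond the scatter: a 37-fold lower number from compound 3 to compound 4 (1.57 log units; beyond the scatter) and an 8.0-fold lower number from compound 2 to compound 4 (0.91 log units; beyond the scatter). So a ring on the carbonyl carbon need not be non-aromatic, and here the aromatic one does better. The step of an at least 1100-fold lower number from compound 1 to compound 4 (3.06 log units; beyond the scatter) is the widest yet, but compound 1 stands at a limit, not a number: the limit of > 10000 nM in this assay, at which 1 of the 4 values shown sits.

Whether the aromatic ring or its chlorine accounts for these steps stays open. So does how phenyl without the chlorine, or a pyridine ring, would read in this assay.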